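The source may report more compounds than this note shows. Statements on the series, on what has been measured and on what is new or still open speak of the compounds shown alone.

Compound 1 `CN(C)c1ccc(/C=C2\CCC/C(=C\c3ccccc3[N+](=O)[O-])C2=O)cc1` was tested in a functional assay on MOLT-4 cells (Homo sapiens) for cytotoxicity, with a stated time of 72 h (a higher number here means a weaker inhibitor, a lower number a stronger inhibitor), where it gives 122000 nM. Among the three measured compounds this is the highest number, so compound 1 is the weakest of the set, its steps to both others lying beyond the scatter. Its nearest neighbour is compound 3 `Cc1ccc(/C=C2\CCC/C(=C\c3ccc([N+](=O)[O-])cc3)C2=O)cc1`, which in this assay gives 8440 nM. Compound 2 `O=C1CCCC/C1=C\c1cccc([N+](=O)[O-])c1`, which carries a single nitro-bearing arm on the core, gives 8280 nM in this assay, also far lower than compound 1. Among the measured compounds shown here, no two measured compounds differ in just one place, so no single step can be read off directly.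

Compound 4 `O=C1/C(=C/c2ccc(F)cc2)CCC/C1=C\c1ccccc1[N+](=O)[O-]` is not yet measured. It keeps the core of compound 1 and differs by fluoro in place of dimethylamino on an aromatic carbon, para to a large group. For the measured compounds named here, the only guide is compound 3, which carries a methyl group rather than a dimethylamino group and gives 8440 nM. A step toward a lower number is therefore expected, an 8.1-fold lower number from compound 1 to compound 4 (0.91 log units; beyond the scatter) in size. Compound 4 is estimated at 15000 nM, within a range from 4000 nM to 60000 nM.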

Compound 4, half-maximal inhibitory concentration: 1870 nM
Beside the measured number, compound 4's estimate is 8.0-fold (0.90 log units) above it; the whole stated range lies above it.
By their numbers in this assay, from the lowest: compound 4; then compounds 2 and 3 (each within the scatter of the next); then compound 1.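

Among the compounds shown here, this is the first pair in the set that differs in only one place, so a single change can now be read directly: in this assay, replacing 4-(dimethylamino)phenyl with 4-fluorophenyl gives a 65-fold lower number from compound 1 to compound 4 (1.81 log units; beyond the scatter). With the nitro-bearing arm and the rest of the core unchanged, the group on this aromatic carbon, para to a large group, clearly has a strong bearing on the result. No measurement offered here explains the size of this drop.

As far as these compounds go, with only these two groups compared at this position, it remains open whether the gain comes from losing dimethylamino or from adding fluoro. Chloro, methoxy or a plain hydrogen on the same carbon, with the rest of compound 1 unchanged, would help separate those two readings.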